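A few compounds are considered here, and "the series" means these few. Any claim that something is new, unique, unknown or untested is made for them only; others in the source may bear on it.

Of the compounds shown here, two with a shared core have been tested in a functional assay on SW-620 cells (Homo sapiens) for cytotoxicity, read by sulforhodamine B assay, with a stated time of 48 h, tested at 100 nM; on this read-out higher numbers stand for a weaker effect at the one concentration tested and lower numbers for a stronger effect. Compound 1, `Cc1cc(O)cc(-c2nn(CC#N)cc2-c2ccnc(-c3ccc(Oc4ccccc4)cc3)c2)c1`, gives 92% in this assay. Compound 2, `COc1cc(C)cc(-c2nn(CC#N)cc2-c2ccnc(-c3ccc(N(C)C)cc3)c2)c1`, gives 14% in this assay, the lowest of the two numbers and the stronger effect; its nearest neighbour is compound 1, whose number is higher by a gap beyond the scatter. The two compounds differ in two places, so their gap cannot be pinned on one change. Compound 3, `Cc1cc(O)cc(-c2nn(CC#N)cc2-c2ccnc(-c3ccc(N(C)C)cc3)c2)c1`, is not yet measured. It keeps the dimethylamino group of compound 2 and differs from it in one place: hydrogen in place of methyl on an oxygen on an aromatic ring. Among the measured compounds shown here, with no single-change step known, the expected step from compound 2 to compound 3 is a moderate rise toward a weaker effect, a number 16 percentage points higher from compound 2 to compound 3 (beyond the scatter), near the edge of the scatter. Compound 3 is therefore expected to give about 30% in this assay, within a range from 10% to 70%.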

Compound 3, a percentage reported as activity, at one concentration (the size of the read-out at that concentration, not a potency): 83%
The estimate for compound 3 lay 53 percentage points below the measured number, and the stated range ends below it.
By their numbers in this assay, from the lowest: compound 2; then compounds 3 and 1 (each within the scatter of the next).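

In this assay, the change from methoxy to hydroxy on the 3-methoxy-5-methylphenyl group is a large one, a number 69 percentage points higher from compound 2 to compound 3 (beyond the scatter), so on this oxygen a single methyl separates a strong effect from a weak one. With the hydroxy group kept, putting dimethylamino in place of phenoxy gives a number 9 percentage points lower from compound 1 to compound 3 (within the scatter), which lies within the scatter, so this swap shows no readable effect while the hydroxy group is present. The data shown offer no measurement that explains either step.

On these data alone, it remains open whether the phenoxy group would keep the strong effect alongside methoxy, since the dimethylamino group has been seen with it only so far. As far as these compounds go, it is also open whether methyl is special on this oxygen or whether a longer chain, such as an ethyl group, or an amine in place of the oxygen would serve as well.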